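This account rests on a few compounds, and the source may have more. Where it says the series, first, only, none or still open, it means among the compounds named here.

Measured in a functional assay on MKN-45 cells (Homo sapiens) for cytotoxicity, read by MTT assay, with a stated time of 72 h; a lower number here means a stronger inhibitor, a higher number a weaker inhibitor:
compound 1 `COc1cc2c(Oc3ccc(NC(=O)c4cc(-c5ccccc5)ccn4)cc3F)ccnc2cc1OCCCN1CCN(C)CC1` gives 150 nM
compound 2 `COc1ccc(-c2ccnc(C(=O)Nc3ccc(Oc4ccnc5cc(OCCCN6CCN(C)CC6)c(OC)cc45)c(F)c3)c2)cc1` gives 250 nM
compound 3 `COc1cc2c(Oc3ccc(NC(=O)c4cc(-c5ccccc5)ccn4)cc3F)ccnc2cc1OCCCN1CCCC1` gives 210 nM

Compound 3 sits at the second highest of the three numbers in this assay; its nearest neighbour is compound 2 and its furthest is compound 1, and both gaps fall within the usual scatter, so no order among the three can be read from these numbers. Compound 4 `COc1cc2c(Oc3ccc(NC(=O)c4cc(-c5ccc(C)cc5)ccn4)cc3F)ccnc2cc1OCCCN1CCCC1` differs from compound 3 only in methyl in place of hydrogen on an aromatic carbon. Two measured steps exist. a 1.4-fold higher number from compound 1 to compound 3 (0.15 log units; within the scatter) concerns the amine on the chain and does not bear on a change at the phenyl; it only places compound 3 beside compound 1. a 1.7-fold higher number from compound 1 to compound 2 (0.22 log units; within the scatter) is the closer comparison, since it too adds a substituent to an aromatic ring where before there was none, and it stayed within the scatter. Nothing measured here shows that a methyl in place of hydrogen on the phenyl would move this assay appreciably, so the step from compound 3 to compound 4 is expected to be small, a 1.1-fold higher number from compound 3 to compound 4 (0.04 log units; within the scatter), with no direction beyond the scatter. Compound 4 is therefore estimated at 230 nM, with a range of 100 nM to 520 nM in this assay.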

Compound 4, half-maximal inhibitory concentration: 440 nM
The estimate for compound 4 lay 1.9-fold (0.28 log units) below the measured number; measured number inside the range.
By their numbers in this assay, from the lowest: compounds 1, 3, 2 and 4 (each within the scatter of the next, the first and the last beyond it).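

In this assay, phenyl to 4-methylphenyl gives a 2.1-fold higher number from compound 3 to compound 4 (0.32 log units; beyond the scatter), a modest step towards weaker inhibition, but the first substitution on this six-membered aromatic ring of carbon only that lies beyond the scatter. So a single added carbon, para to a large group, is enough to register here, which the methoxy step a 1.7-fold higher number from compound 1 to compound 2 (0.22 log units; within the scatter) did not show, though that step was read with 4-methylpiperazin-1-yl on the chain and this one with pyrrolidin-1-yl. No measurement at hand accounts for the step, so it stands as an observation without an explanation.

Open, from the compounds shown here alone, is whether the step belongs to the methyl itself or to any group on this carbon, which a chloro, trifluoromethyl or hydroxyl group at the same place would begin to separate. Also open, going by these compounds, is whether the methyl gives a similar step with 4-methylpiperazin-1-yl on the chain, since the pair in hand carries only pyrrolidin-1-yl.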